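The compounds below may be only part of what the source reports. "The series", "measured", "known", "first", "only" and "open" are said of these compounds alone.

Compound 1, `COc1cc(N2CCCNCC2)cnc1Cl`, gives 0.676 nM.
Compound 2, `Oc1cc(N2CCCNCC2)cnc1I`, gives 21.9 nM.
Compound 3, `COc1cncc(N2CCCNCC2)c1`, gives 1.91 nM.

All three values come from an assay on HEK293 cells for displacement of a labelled ligand from Neuronal acetylcholine receptor; alpha4/beta2 (Homo sapiens); a lower number here means a stronger inhibitor, a higher number a weaker inhibitor. Among them compound 3 holds the second highest number: compound 1 lies nearest, with a 2.8-fold higher number from compound 1 to compound 3 (0.45 log units; beyond the scatter) separating the two, while compound 2 sits furthest away with a much higher number than compound 3.

The step now considered leads from compound 3 to compound 4, `Oc1cncc(N2CCCNCC2)c1`. The change is hydrogen in place of methyl on an oxygen on an aromatic ring; read one bond further out, it is methoxy turning into hydroxy. Among the compounds with values here, no single measured step describes this change directly. The one listed step, the removal of chloro from compound 1 to compound 3, concerns a different position and only shows that the shared core tolerates small edits with modest movement. Compound 1 and compound 2 differ in two places at once, one of them this same methoxy-to-hydroxy exchange, and compound 2 shows a far higher number than compound 1. On that slender basis a rise in the number is expected for compound 4, with a 7.9-fold higher number from compound 3 to compound 4 (0.90 log units; beyond the scatter) as the estimated step. Compound 4 is therefore expected to give about 15 nM, within a range of 4 nM to 60 nM.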

Compound 4, half-maximal inhibitory concentration: 2.4 nM
For compound 4 the middle estimate is 6.3-fold (0.80 log units) above the measured one, and the stated range ends above it.
By their numbers in this assay, from the lowest: compound 1; then compounds 3 and 4 (each within the scatter of the next); then compound 2.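

Seen alone for the first time, the exchange of methoxy for hydroxy on the aromatic ring moves the number only within the scatter (a 1.3-fold higher number from compound 3 to compound 4 (0.10 log units; within the scatter)), so in this halogen-free pair the methyl on the oxygen can give way to hydrogen without a measurable change. With the hydroxy kept in place, removing the iodo gives a much larger step (a 9.1-fold lower number from compound 2 to compound 4 (0.96 log units; beyond the scatter)), which shows that the high number of compound 2 does not come from the hydroxy alone. Nothing shown here explains either step.

Still open, as far as these compounds go, is whether the exchange behaves the same way when a chloro or iodo group is present on the aromatic carbon. Also open, from the compounds shown here alone, is how an ethyl group or a longer chain on that oxygen, or an amine in place of the hydroxy, would read.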